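This account rests on a few compounds, and the source may have more. Where it says the series, first, only, none or still open, it means among the compounds named here.

Values in a toxicity assay on HepG2 2.2.15 cells (Homo sapiens) for cytotoxicity, read by CellTiter-Glo; a lower number here means that less compound is tolerated, a higher number that more compound is tolerated:
Compound 1 `O=C1CC(Oc2ncc(F)cn2)CN1c1cnn2c1CN(C(=O)Nc1cc(F)c(F)c(F)c1)C(C1CC1)C2`: 96200 nM
Compound 2 `O=C1CC(c2ncc(F)cn2)CN1c1cnn2c1CN(C(=O)Nc1cc(F)c(F)c(F)c1)C(C1CC1)C2`: 115000 nM

Only these two numbers are available, and compound 2 stands within the scatter of compound 1. The next structure is compound 3 `O=C1CC(c2ncco2)CN1c1cnn2c1CN(C(=O)Nc1cc(F)c(F)c(F)c1)C(C1CC1)C2`, which differs from compound 2 on a saturated ring carbon: 1,3-oxazol-2-yl in place of 5-fluoropyrimidin-2-yl on a saturated ring carbon. Going by the values given here, one measured step bears on this change, and only in part: a 1.2-fold higher number from compound 1 to compound 2 (0.08 log units; within the scatter). Among the compounds with values here, that step also falls on a saturated ring carbon, but 5-fluoropyrimidin-2-yl remains in place, and no measured compound carries 1,3-oxazol-2-yl. In this assay, no step beyond the scatter is therefore expected in either direction, although the evidence is thin. The expected step is a 1.2-fold lower number from compound 2 to compound 3 (0.06 log units; within the scatter). For compound 3 the estimated value is 100000 nM, with an expected range of 50000 nM to 200000 nM.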

Compound 3, half-maximal cytotoxic concentration: > 200000 nM
Compound 3 gave a limit, no number; the forecaster's own chance of this, stated with the estimate: 25%; middle value at least 2.0-fold (0.30 log units) from the limit.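

In this assay compound 3 gives a limit of the assay and not a number: the limit of > 200000 nM in this assay, at which 1 of the 3 values shown sits. Placing 1,3-oxazol-2-yl on this saturated ring carbon in place of 5-fluoropyrimidin-2-yl gives an at least 1.7-fold higher number from compound 2 to compound 3 (0.24 log units; that floor lies within the scatter), so this floor alone does not separate the two groups. Going by these compounds alone, in place of (5-fluoropyrimidin-2-yl)oxy, the same group gives an at least 2.0-fold higher number from compound 1 to compound 3 (0.31 log units; beyond the scatter), the only step on this carbon that passes the scatter, unlike a 1.2-fold higher number from compound 1 to compound 2 (0.08 log units; within the scatter).

On these data alone, how far compound 3 lies past its limit stays open, so the full size of both steps cannot be read. Also open, as far as these compounds go, is how an amine or a carboxylic acid on this saturated ring carbon would read in this assay.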